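The compounds below may be only part of what the source reports. "The series", "measured", "known", "first", "only" and "open" are said of these compounds alone.

Of the compounds shown here, three of a shared urea series have been measured in an assay on HEK293 cells for displacement of a labelled ligand from transient receptor potential cation channel subfamily V member 1 (Homo sapiens); a higher number here means a weaker inhibitor, a lower number a stronger inhibitor. Compound 1 `O=C(Nc1cccc2cnccc12)NC1CCc2cc(F)ccc2C1Cc1ccoc1` gives 16 nM. Compound 2 `COc1ccc2c(c1)CCC(NC(=O)Nc1cccc3cnccc13)C2Cc1cccnc1` gives 1540 nM, and compound 3 `COc1ccc(CC2c3ccc(OC)cc3CCC2NC(=O)Nc2cccc3cnccc23)cc1` gives 8 nM. Compound 1 therefore sits second of the three: its number is within the scatter of that of compound 3, while compound 2 lies far above both.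

Compound 4 `O=C(Nc1cccc2cnccc12)NC1CCc2cc(F)ccc2C1Cc1ccc(C(F)(F)F)cc1` differs from compound 1 in one place: 4-(trifluoromethyl)phenyl in place of furan-3-yl on a saturated chain carbon bound to a saturated ring carbon. Among the compounds with values here, no measured pair shows exactly this exchange. Within the data shown here, the only step at the same place is a 190-fold lower number from compound 2 to compound 3 (2.28 log units; beyond the scatter), which shows that swapping the aromatic group on this chain carbon can move the number a long way. That step replaced a nitrogen-containing ring with a methoxy-bearing phenyl; here a furan gives way to a phenyl carrying trifluoromethyl, a different pair, so its size cannot simply be carried over. The change is expected to stay modest, a 1.3-fold lower number from compound 1 to compound 4 (0.12 log units; within the scatter), with the direction uncertain. Compound 4 is thus estimated to give about 12 nM in this assay, within a range from 3 nM to 50 nM.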

Compound 4, inhibition constant: 1 nM
For compound 4 the middle estimate is 12-fold (1.08 log units) above the measured one; measured number outside the range, below it.
By their numbers in this assay, from the lowest: compound 4; then compounds 3 and 1 (each within the scatter of the next); then compound 2.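

In this assay, a 16-fold lower number from compound 1 to compound 4 (1.20 log units; beyond the scatter) shows that this chain carbon is sensitive to its aromatic group even when the starting compound already has a low number. Together with a 190-fold lower number from compound 2 to compound 3 (2.28 log units; beyond the scatter), it gives a second case, in a separate pair of compounds, where a phenyl group with a substituent in the 4-position replaces a heteroaromatic ring and the number falls well beyond the scatter. No measurement is available that explains the size of this step.

The step changes the ring and its substituent together, and the compounds shown do not separate the two contributions. A plain benzyl group would help to separate them, while a 4-chlorobenzyl or a 4-(dimethylamino)benzyl group would test whether trifluoromethyl can be replaced at this place.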